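Swapping the piperazine substituent in an antiproliferative series

A few compounds are considered here, and "the series" means these few. Any claim that something is new, unique, unknown or untested is made for them only; others in the source may bear on it.

Of the compounds shown here, three sharing one core have been tested in a functional assay on HeLa cells (Homo sapiens) for antiproliferative activity, read by CCK-8 assay, with a stated time of 72 h, tested at 8 uM; on this read-out higher numbers stand for a stronger effect at the one concentration tested and lower numbers for a weaker effect. Compound 1 `Nc1ccccc1NC(=O)c1ccc(CSC(=S)N2CCN(c3ccc(Cl)cc3)CC2)cc1` gives 44.8%, the lowest of the three numbers. Compound 2 `CC1CCN(C(=S)SCc2ccc(C(=O)Nc3ccccc3N)cc2)CC1` gives 72.5% and compound 3 `CN(Cc1ccncc1)C(=S)SCc1ccc(C(=O)Nc2ccccc2N)cc1` gives 72.7%, both beyond the scatter above compound 1. Among the compounds with values here, the one measured step, a number 0.2 percentage points higher from compound 2 to compound 3 (within the scatter), exchanges the whole group on the thiocarbonyl carbon and lies within the scatter.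

Compound 4 `Nc1ccccc1NC(=O)c1ccc(CSC(=S)N2CCN(Cc3ccccc3)CC2)cc1` differs from compound 1 in one place: benzyl in place of 4-chlorophenyl on an amine nitrogen in a ring. Within the data shown here, no measured step touches that ring nitrogen, so the direction is open; the values of compound 2 and compound 3 only show that this core can reach higher numbers. Compound 4 is therefore expected to land near compound 1 or somewhat above, with an estimated step of a number 10.2 percentage points higher from compound 1 to compound 4 (beyond the scatter). The estimate for compound 4 is 55%, within 35% to 75%.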

Compound 4, a percentage reported as inhibition, at one concentration (the size of the read-out at that concentration, not a potency): 31.3%
Compound 4: the middle estimate sits 23.7 percentage points above what was measured; the measured number lies below the stated range.
By their numbers in this assay, from the lowest: compound 4; then compound 1; then compounds 2 and 3 (each within the scatter of the next).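

In this assay, the group on this ring nitrogen matters: benzyl in place of 4-chlorophenyl gives a number 13.5 percentage points lower from compound 1 to compound 4 (beyond the scatter). The two groups have the same heavy-atom count and each holds one six-membered aromatic ring of carbon only, so the number moved although those counts did not. Nothing available accounts for this drop. Still open, going by these compounds, is how an unsubstituted phenyl or a longer chain such as phenylethyl on this ring nitrogen would compare. Those groups could show whether the chlorine or the extra carbon accompanies the step.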